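The compounds below may be only part of what the source reports. "The series", "measured", "known", "first", "only" and "open" are said of these compounds alone.

Compound 2 `COc1cc(C(=O)O)ccc1OCCCCOc1ccc(C(=O)CC(C)(C)C)c(O)c1C` and compound 1 `COc1cc(C(=O)O)ccc1OCCCCOc1ccc(C(=O)CC(C)C)c(O)c1C` share the same core and differ only in one side chain. In an assay on HEK293 cells for positive allosteric modulation of metabotropic glutamate receptor 2 (Rattus norvegicus), read by thallium flux, with a stated time of 2.5 min (on this read-out lower numbers stand for an effect already at smaller amounts and higher numbers for an effect only at larger amounts of compound), compound 1 gives 40 nM and compound 2 gives 47 nM; the two numbers sit within the usual scatter of each other, so neither stands apart. Among the measured compounds shown here, the only measured step, a 1.2-fold higher number from compound 1 to compound 2 (0.07 log units; within the scatter), thus shows no real change. Compound 3 `CCC(=O)c1ccc(OCCCCOc2ccc(C(=O)O)cc2OC)c(C)c1O` carries methyl in place of tert-butyl on a saturated chain carbon bound to a carbonyl carbon, a deeper cut of that same chain than the measured step covered. With that step inside the scatter, only a modest shift is expected: a 1.7-fold higher number from compound 2 to compound 3 (0.23 log units; within the scatter). For compound 3 the value expected in this assay is 80 nM, within 30 nM to 250 nM.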

Compound 3, half-maximal effective concentration: 114 nM
Compound 3: the middle estimate sits 1.4-fold (0.15 log units) below what was measured; the range from low to high includes it.
By their numbers in this assay, from the lowest: compounds 1 and 2 (each within the scatter of the next); then compound 3.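

In this assay the size of the chain end on a saturated chain carbon bound to a carbonyl carbon does matter once it is cut back far enough. Methyl in place of tert-butyl gives a 2.4-fold higher number from compound 2 to compound 3 (0.38 log units; beyond the scatter) and methyl in place of isopropyl gives a 2.9-fold higher number from compound 1 to compound 3 (0.45 log units; beyond the scatter) so methyl stands apart, though only modestly, while the two larger ends stay within the scatter of each other. No measurement shown explains this gap. On these data alone, whether a longer chain or an amine at this place would bring the number back down or push it higher stays open.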